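The compounds below may be only part of what the source reports. "The series", "measured", "known", "first", "only" and "open" are said of these compounds alone.

Working notes on the series built on the shared core of compound 1 (`O=C(Nc1ccc2c(c1)B(O)OC2)c1ccccc1F`), followed in a functional assay on PBMC cells (Homo sapiens) for inhibition, read by HTRF, with stated times of 15 min and 24 h; a higher number here means a weaker inhibitor, a lower number a stronger inhibitor. Compound 1 gives only a limit, > 10000 nM. Compound 2 (`O=C(Nc1ccc2c(c1)B(O)OC2)c1ccc(C(F)(F)F)cc1`) likewise gives only a limit, > 100000 nM, so it stands without a numerical value in this assay. The next change leads to compound 3 (`O=C(Nc1ccc2c(c1)B(O)OC2)c1ccc(C(F)(F)F)cc1F`): fluoro in place of hydrogen on an aromatic carbon, ortho to a large group and meta to a trifluoromethyl group. Among the compounds with values here, no measured step gives the size of such a change. A shift toward stronger inhibition is still expected, on thin support: compound 1, which also carries a fluoro, has the limit > 10000 nM. The expected change is an at least 6.6-fold lower number from compound 2 to compound 3 (0.82 log units; beyond the scatter). Compound 3 is estimated at 15000 nM, with an expected range of 1500 nM to 100000 nM.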

Compound 3, half-maximal inhibitory concentration: > 100000 nM
Compound 3: no number, only a limit; the forecaster's own chance of this, stated with the estimate: 50%; at least 6.6-fold (0.82 log units) between middle value and limit.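

Compound 1, compound 2 and compound 3 all give only limits in this assay, so neither the step from compound 2 to compound 3 nor the step from compound 1 to compound 3 can be read. The compounds shown leave open whether adding fluoro or trifluoromethyl changes inhibition at all.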